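Phenyl for methyl on a shared five-ring core

The source may report more compounds than this note shows. Statements on the series, on what has been measured and on what is new or still open speak of the compounds shown alone.

Measured compounds:
Compound 1 `Cc1oc2c3c(ccc2c(=O)c1C)OC[C@H]1[C@@H]3C2=C(CC(C)(C)CC2=O)OC1(C)C` — in a functional assay on MDA-MB-231 cells (Homo sapiens) for antiproliferative activity, read by MTT assay, with a stated time of 48 h (on this read-out higher numbers stand for weaker inhibition and lower numbers for stronger inhibition), compound 1 gives only a limit, > 100000 nM.
Compound 2 `Cc1coc2c3c(ccc2c1=O)OC[C@H]1[C@@H]3C2=C(CC(C)(C)CC2=O)OC1(C)C` — in this assay compound 2 likewise gives only a limit, > 100000 nM.

The step that the two limits leave unreadable from compound 1 to compound 2 cannot be read, because both of its ends sit at a limit (the limit of > 100000 nM in this assay, at which 2 of the 2 values shown sit). Compound 1 therefore stands only at a limit in this assay, with no number of its own. Compound 3 `Cc1oc2c3c(ccc2c(=O)c1-c1ccccc1)OC[C@H]1[C@@H]3C2=C(CC(C)(C)CC2=O)OC1(C)C` has not yet been measured in this assay. It differs from compound 1 by phenyl in place of methyl on an aromatic carbon. Among the measured compounds shown here, the one measured step bears on this change only in that it is unreadable, so its size gives no guide. The data say nothing about how a larger group on that carbon behaves. Compound 3 is expected to stand at about 100000 nM, with a range of 20000 nM to 300000 nM. The step of a number no higher from compound 1 to compound 3 (the limit leaves the size open) is thus expected to be small and is most likely to end at a limit again.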

Compound 3, half-maximal inhibitory concentration: > 100000 nM
Compound 3 was reported as a limit; the forecaster's own chance of this, stated with the estimate: 70%; the middle value sits exactly at the limit.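

In this assay compound 3 gives only a limit, > 100000 nM. The change from compound 1 to compound 3 yields no readable step, because both ends rest on a limit: the limit of > 100000 nM in this assay, at which 3 of the 3 values shown sit. The compounds shown leave open whether any group on that aromatic carbon affects antiproliferative activity, as none of them has a number of its own.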